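This account rests on a few compounds, and the source may have more. Where it says the series, first, only, none or still open, it means among the compounds named here.

The compounds measured so far in an ADME assay on microsomes from liver (Mus musculus, strain CD1) for metabolic stability, read by HPLC, with a stated time of 30 min, tested at 1 uM (on this read-out lower numbers stand for slow clearance and higher numbers for fast clearance), are:

Compound 1 `Cn1cc2c(NS(=O)(=O)c3ccc(Br)cc3)c(N3CCCC3)ccc2n1` gives 33 mL.min-1.g-1
Compound 2 `O=S(=O)(Nc1c(C2CCCCC2)ccc2ncccc12)c1ccc(Br)cc1` gives 38 mL.min-1.g-1
Compound 3 `O=S(=O)(Nc1c(CC2CCCCC2)ccc2ncccc12)c1ccc(Br)cc1` gives 33 mL.min-1.g-1

Compound 2 at 38 mL.min-1.g-1 lies within the scatter of both compound 1 and compound 3, so these three numbers cannot be ranked. The next compound to be measured is compound 4 (`O=S(=O)(Nc1c(Cc2ccccc2)ccc2ncccc12)c1ccc(Br)cc1`), which differs from compound 2 by one change: benzyl in place of cyclohexyl on an aromatic carbon. The incoming group brings a six-membered aromatic ring of carbon only where a non-aromatic ring stood before.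

Going by the values given here, one measured step bears on this change: cyclohexylmethyl in place of cyclohexyl on an aromatic carbon (a 1.2-fold lower number from compound 2 to compound 3 (0.06 log units; within the scatter)). That step stayed within the scatter, but it involves no aromatic ring. Among the compounds with values here, no measured step exchanges a non-aromatic ring for an aromatic one, so that part of the change remains untested and the range has to stay wide. In this assay no step beyond the scatter is expected, and the data favour no direction. The expected step is small (a 1.1-fold lower number from compound 2 to compound 4 (0.04 log units; within the scatter)). Compound 4 is estimated at 35 mL.min-1.g-1 (expected range 17 mL.min-1.g-1 to 70 mL.min-1.g-1).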

Compound 4, intrinsic clearance in microsomes: 23 mL.min-1.g-1
The estimate for compound 4 lay 1.5-fold (0.18 log units) above the measured number; the measured number falls inside the stated range.
By their numbers in this assay, from the lowest: compounds 4, 1, 3 and 2 (each within the scatter of the next).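

In this assay, going by these compounds alone, the first exchange of a non-aromatic ring for an aromatic one at this position gives a 1.7-fold lower number from compound 2 to compound 4 (0.22 log units; within the scatter), and the comparison that keeps the saturated chain carbon in place, phenyl for cyclohexyl, gives a 1.4-fold lower number from compound 3 to compound 4 (0.16 log units; within the scatter). Read either way, the change stays inside the scatter, so across cyclohexyl, cyclohexylmethyl and benzyl on this aromatic carbon, neither the aromatic ring nor the extra chain carbon has yet produced a step that can be told from repeat measurement. Nothing available gives a measured reason for where these numbers fall.

As far as these compounds go, all three groups compared on this core contain carbon only, so it remains open whether a pyridylmethyl group, an amine or a carboxylic acid at this place would move the clearance number beyond the scatter. Compound 1 differs from the others in more than one place and cannot settle this, which leaves the position's effect on clearance unresolved beyond these carbon-only groups.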